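A few compounds are considered here, and "the series" means these few. Any claim that something is new, unique, unknown or untested is made for them only; others in the source may bear on it.

Of the compounds shown here, three built on one shared core have been tested in a functional assay on PC-12 cells (Rattus norvegicus) for cytotoxicity, read by MTT assay, with stated times of 2 h and 24 h, tested at 1 uM; a higher number here means a stronger effect of the compound at the concentration tested, a lower number a weaker effect. Compound 1 `CCc1ccc(-n2nc(-c3ccc(C(F)(F)F)cc3O)nc2-c2ccccc2O)cc1` gives 64.4%. Compound 2 `Oc1cc(C(F)(F)F)ccc1-c1nc(-c2ccccc2O)n(-c2ccc(C(F)(F)F)cc2)n1` gives 70.7%, and compound 3 `Oc1cc(C(F)(F)F)ccc1-c1nc(-c2ccccc2O)n(-c2ccc(OC(F)(F)F)cc2)n1` gives 65.5%. The three numbers lie close together, and compound 1 cannot be set apart from the other two: the step of a number 6.3 percentage points higher from compound 1 to compound 2 (within the scatter), the step of a number 1.1 percentage points higher from compound 1 to compound 3 (within the scatter) and the step of a number 5.2 percentage points lower from compound 2 to compound 3 (within the scatter) all fall within the scatter of repeated measurements.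

Compound 4 `Oc1cc(C(F)(F)F)ccc1-c1nc(-c2ccccc2O)n(-c2ccc(Cl)cc2Cl)n1` has not yet been measured in this assay. Compared with compound 1 it carries a different group on the aromatic nitrogen of the shared core: 2,4-dichlorophenyl in place of 4-ethylphenyl on an aromatic nitrogen. The three measured steps are the ones that bear on this, since each of them exchanges one group for another on an aromatic carbon of that same ring on the nitrogen, and none of them moved the read-out beyond the scatter. Among the measured compounds shown here, the new change swaps the whole ring on the nitrogen rather than one group on it, so it is larger than any step measured here, but there is no measured step pointing in either direction. The expected step is therefore a number 2.6 percentage points higher from compound 1 to compound 4 (within the scatter), which is none beyond the scatter. Compound 4 is estimated to give 67%, with a range from 55% to 79%.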

Compound 4, a percentage reported as activity, at one concentration (the size of the read-out at that concentration, not a potency): 69%
Estimate against measurement, compound 4: 2 percentage points below; low and high end bracket the measured number.
By their numbers in this assay, from the lowest: compounds 1, 3, 4 and 2 (each within the scatter of the next).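

Among the compounds shown here, exchanging the whole ring on the aromatic nitrogen, and not only one group on it, still does not move the read-out in this assay beyond the scatter: the steps of a number 4.6 percentage points higher from compound 1 to compound 4 (within the scatter) and a number 3.5 percentage points higher from compound 3 to compound 4 (within the scatter) and a number 1.7 percentage points lower from compound 2 to compound 4 (within the scatter) are all small. The earlier compounds shown here each carried a single group on this ring, so compound 4 adds something new: a ring with two chlorine atoms, 2,4-dichlorophenyl, gives a read-out that cannot be told apart from those of the three rings with a single group. No measurement shown here offers an explanation for why the read-out stays so level across these four rings.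

Going by these compounds, all four compounds keep a six-membered aromatic ring of carbon only on this nitrogen, so it remains open whether a pyridine ring, a saturated cyclohexyl ring, or a phenyl ring bearing an amine or a carboxylic acid would move the read-out beyond the scatter. Also open, on these data alone, is what happens when the 2-hydroxyphenyl group on the shared core is changed, since it stays the same throughout these compounds.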